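Replacing phenylcyclobutyl with pyridinylcyclopropyl in a dog half-life series

The compounds below may be only part of what the source reports. "The series", "measured", "known", "first", "only" and "open" are said of these compounds alone.

Of the compounds shown here, two have been measured in an in vivo ADME assay on the whole organism with Canis familiaris (Canis lupus familiaris) as the target; a higher number here means that the compound lasts longer, a lower number that the compound disappears faster. Compound 1 `Cc1cnc(NCC2(c3ccccc3)CCC2)c(=O)n1CC(=O)NCc1ccc2c(N)noc2c1` is the lower of the two: in this assay compound 1 gives 1.95 h. Among the measured compounds shown here, compound 2 `COc1cccc(S(=O)(=O)Nc2cccn(CC(=O)NCc3ccc4[nH]nc(N)c4c3)c2=O)c1` differs from it in many places and shares no single-point step with it; in this assay compound 2 gives 4.57 h, a number beyond the scatter above that of compound 1. Nothing else ties the two values together, so no trend can be drawn from them.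

Compound 3 `Cc1cnc(NCC2(c3ccccn3)CC2)c(=O)n1CC(=O)NCc1ccc2c(N)noc2c1` has not yet been measured. It differs from compound 1 in one place: 1-(pyridin-2-yl)cyclopropyl in place of 1-phenylcyclobutyl on a saturated chain carbon bound to a nitrogen on an aromatic ring. For the measured compounds named here, no measured pair shows this kind of change, so the size of its effect is unknown. Because the only firm point is 1.95 h for compound 1, the expectation is that compound 3 lies close to it, with a step from compound 1 to compound 3 of a 1.1-fold higher number from compound 1 to compound 3 (0.05 log units; within the scatter) that is not expected to exceed the scatter in either direction. In this assay compound 3 is therefore estimated at 2.2 h, within a range from 1 h to 4.5 h.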

Compound 3, half-life: 1.67 h
Compound 3: the middle estimate sits 1.3-fold (0.12 log units) above what was measured, within the range that was stated.
By their numbers in this assay, from the lowest: compounds 3 and 1 (each within the scatter of the next); then compound 2.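

In this assay, among the compounds shown here, the pair gives the first reading of a single change at this position, with a 1.2-fold lower number from compound 1 to compound 3 (0.07 log units; within the scatter) when 1-(pyridin-2-yl)cyclopropyl stands in place of 1-phenylcyclobutyl on a saturated chain carbon bound to a nitrogen on an aromatic ring. This one swap replaces a four-membered carbon ring with a three-membered one and a six-membered aromatic ring of carbon only with one holding 1 hetero atom and 1 hydrogen-bond acceptor, yet the step stays within the scatter, so the two structures cannot be told apart by their half-lives. No supporting measurement bears on why the number holds across this swap.

For the compounds shown here, the two ring changes arrive together, so the pair cannot assign a share of the step to either one, and it leaves open how 1-phenylcyclopropyl or 1-(pyridin-2-yl)cyclobutyl, each carrying only one of the two changes, would behave. It also leaves open whether a more drastic group at this place, such as a carboxylic acid or an amine on the aromatic ring, would carry the half-life beyond the scatter in either direction.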